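Azido to Chloro on the Methylene Arm: Vero Cell Tolerance

The source may hold more compounds than are shown below. What is called first, only, known or untested is meant among the compounds shown, and "the series" means these compounds.

Compound 1 `CC(C)[C@@H](Nc1nc(Cl)nc2c1ncn2[C@H]1[C@H](O)[C@H](O)[C@]2(CN=[N+]=[N-])C[C@H]12)C1CC1`: 32000 nM
Compound 2 `O[C@@H]1[C@H](O)[C@@H]2C[C@@H]2[C@H]1n1ccc2c(NC(C3CC3)C3CC3)nc(I)nc21`: 100000 nM
Compound 3 `CC(C)(O)[C@@H](Nc1nc(Cl)nc2c1ccn2[C@H]1[C@H](O)[C@H](O)[C@]2(CO)C[C@H]12)C1CC1`: > 100000 nM

Of the compounds shown here, three have been tested in an ADME assay on Vero 76 cells (Chlorocebus sabaeus) for cytotoxicity, read by microscopy; a lower number here means that less compound is tolerated, a higher number that more compound is tolerated. Compound 1 gives 32000 nM, the lowest of the two numbers that were obtained. Compound 2 gives 100000 nM, a higher number, and the gap to compound 1 lies beyond the usual scatter of this assay. Compound 3 gives > 100000 nM, which is a limit of the assay and not a number (the limit of > 100000 nM in this assay, at which 1 of the 3 values shown sits).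

The compound that remains to be measured is compound 4 `CC(C)[C@@H](Nc1nc(Cl)nc2c1ncn2[C@H]1[C@H](O)[C@H](O)[C@]2(CCl)C[C@H]12)C1CC1`. It is built from compound 1 by a single change: chloro in place of azido on a saturated chain carbon bound to a saturated ring carbon. Among the measured compounds shown here, no pair of measured compounds differs in this one place, so there is no measured step to lean on, and the other two measured compounds differ from compound 1 in more than one place at once.

For the measured compounds named here, with no comparable step in hand, compound 4 is expected to stay close to compound 1, with a step from compound 1 to compound 4 of a 1.1-fold lower number from compound 1 to compound 4 (0.03 log units; within the scatter) that is expected to fall within the usual scatter. Compound 4 is therefore estimated at 30000 nM in this assay, with a range from 8000 nM to 100000 nM.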

Compound 4, half-maximal cytotoxic concentration: 32000 nM
Compound 4: the middle estimate sits 1.1-fold (0.03 log units) below what was measured; the range from low to high includes it.
By their numbers in this assay, from the lowest: compounds 1 and 4 (each within the scatter of the next); then compound 2.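

In this assay, among the compounds shown here, the change from azidomethyl to chloromethyl gives no change at the digits printed from compound 1 to compound 4 (within the scatter), the first comparison that isolates one place. It shows that, on a saturated chain carbon bound to a saturated ring carbon, the three nitrogen atoms of azido can give way to a single chlorine with no measurable shift in cell tolerance, something neither compound 2 nor compound 3 could show, as each differs from compound 1 in more than one place. The value of compound 3 is a limit of the assay and not a number, so it offers no step here, whereas this step rests on two actual numbers: the limit of > 100000 nM in this assay, at which 1 of the 4 values shown sits.

The compounds shown leave open whether this place stays as unresponsive with an amine, a carboxylic acid or a longer chain on the ring carbon, as azido and chloro are the only two groups compared there. They also leave open whether chloro in place of azido would read the same on the cores of compound 2 and compound 3, which carry other groups elsewhere.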